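Working notes: from compound 3 to compound 4

The compounds below may be only part of what the source reports. "The series", "measured", "known", "first", "only" and "open" are said of these compounds alone.

In a functional assay on MCF7 cells (Homo sapiens) for antiproliferative activity, read by MTT assay, with a stated time of 48 h (on this read-out higher numbers stand for weaker inhibition and lower numbers for stronger inhibition), compound 1 `CCN(CC)CCNC(=O)c1ccc(C(CC)(CC)c2ccc(OCCC(O)(CC)CC)c(C)c2)n1CC` gives 550 nM. Compound 2 `C=CCN(C)C(=O)c1ccc(C(CC)(CC)c2ccc(OCCC(O)(CC)CC)c(C)c2)n1CC` reads > 50000 nM, which is a limit and not a number. Compound 3 `C#CC(C)OC(=O)c1ccc(C(CC)(CC)c2ccc(OCCC(O)(CC)CC)c(C)c2)n1CC` reads > 50000 nM, also a limit and not a number, so it sits at the shared ceiling (the limit of > 50000 nM in this assay, at which 2 of the 3 values shown sit). Compound 4 `CCOc1ccc(NC(=O)c2ccc(C(CC)(CC)c3ccc(OCCC(O)(CC)CC)c(C)c3)n2CC)cc1` carries (4-ethoxyphenyl)amino in place of (1-methylprop-2-yn-1-yl)oxy on a carbonyl carbon. Two large measured steps bear on this change: an at least 90-fold higher number from compound 1 to compound 2 (1.95 log units; beyond the scatter) and an at least 90-fold higher number from compound 1 to compound 3 (1.95 log units; beyond the scatter). Both remove the (2-(diethylamino)ethyl)amino group, which compound 4 also lacks. The step that the two limits leave unreadable from compound 2 to compound 3 adds no size. In this assay only a small move is therefore expected, an at least 1.2-fold lower number from compound 3 to compound 4 (0.09 log units; that floor lies within the scatter). For compound 4 the estimate is 40000 nM, with an expected range from 10000 nM to 50000 nM.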

Compound 4, half-maximal inhibitory concentration: > 50000 nM
Compound 4 ended at the assay's limit (the forecaster's own chance of this, stated with the estimate: 55%); at least 1.2-fold (0.09 log units) between middle value and limit.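

In this assay compound 4 reads > 50000 nM, which is a limit and not a number. The amide hydrogen stays in place here, which the allyl(methyl)amino and (1-methylprop-2-yn-1-yl)oxy groups do not carry, yet the change on the amide-type nitrogen still gives an at least 90-fold higher number from compound 1 to compound 4 (1.95 log units; beyond the scatter), so that hydrogen alone does not keep the activity. The steps from compound 2 and compound 3 to compound 4 cannot be read, and the ceiling is now widely shared: the limit of > 50000 nM in this assay, at which 3 of the 4 values shown sit.

Still open, going by these compounds, is whether a 2-(dimethylamino)ethyl or 2-(morpholin-4-yl)ethyl group on the amide nitrogen would keep the activity of compound 1. A 2-hydroxyethyl group, with no amine, would test whether the terminal amine is needed at all.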